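The compounds below may be only part of what the source reports. "The series", "measured", "known", "first", "only" and "open" are said of these compounds alone.

For the measured compounds named here, in a functional assay on HepG2 cells (Homo sapiens) for cytotoxicity, read by MTT assay, with a stated time of 72 h (a higher number here means a weaker inhibitor, a lower number a stronger inhibitor), three compounds have numbers so far. Compound 1 (`Nc1ccccc1NC(=O)c1ccc(NC(=S)NCc2ccc(Cl)nc2)cc1`) gives 19000 nM, the highest number of the three, which makes it the weakest of the set, beyond the scatter from both of the others. Compound 2 (`Nc1ccccc1NC(=O)c1ccc(CNC(=O)c2cc3cnccc3[nH]2)cc1`) gives 1700 nM and compound 3 (`Nc1ccccc1NC(=O)c1ccc(NC(=O)NCc2ccc(Cl)nc2)cc1`) gives 2400 nM, two values that lie within the scatter of each other.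

Compound 4 (`Cc1ccc(CNC(=S)Nc2ccc(C(=O)Nc3ccccc3N)cc2)cn1`) has not yet been measured. It differs from compound 1 in one place: methyl in place of chloro on an aromatic carbon. In plain terms, 6-chloropyridin-3-yl becomes 6-methylpyridin-3-yl, with the rest of the molecule unchanged. Going by the values given here, no measured pair shows what this swap does in this assay, so the expectation stays anchored on compound 1 at 19000 nM. The estimated change is a 1.3-fold lower number from compound 1 to compound 4 (0.10 log units; within the scatter), a small one that is expected to stay within the scatter, with no firm direction. Compound 4 is expected at about 15000 nM, with an estimated range from 6000 nM to 40000 nM.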

Compound 4, half-maximal inhibitory concentration: 11000 nM
Compound 4: the middle estimate sits 1.4-fold (0.13 log units) above what was measured, within the range that was stated.
By their numbers in this assay, from the lowest: compounds 2 and 3 (each within the scatter of the next); then compounds 4 and 1 (each within the scatter of the next).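

Replacing 6-chloropyridin-3-yl with 6-methylpyridin-3-yl gives the only direct reading of this position among these compounds, and in this assay the step is a 1.7-fold lower number from compound 1 to compound 4 (0.24 log units; within the scatter). Chloro and methyl, each a single heavy atom on the aromatic carbon next to the ring nitrogen, therefore cannot be told apart in this pair. No supporting measurement is available to explain this result.

Going by these compounds, it remains open whether an amine, a methoxy group or a carboxylic acid at this same place would shift the number beyond the scatter. On these data alone, it is also open whether methyl in place of chloro would give an equally small step on compound 3, which carries the same 6-chloropyridin-3-yl group.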